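The source may report more compounds than this note shows. Statements on the series, on what has been measured and on what is new or still open speak of the compounds shown alone.

Compound 3 `CCN(CC)C(=O)c1ccc(-c2cc(C3=CC(=O)C=CC3=O)no2)s1` and compound 1 `CN(C)C(=O)c1ccc(-c2cc(C3=CC(=O)C=CC3=O)no2)s1` share one core and differ in a single place: dimethylamino in place of diethylamino on a carbonyl carbon. In a functional assay on A549 cells (Homo sapiens) for cytotoxicity, read by XTT assay, with a stated time of 72 h (a higher number here means a weaker inhibitor, a lower number a stronger inhibitor), compound 3 gives 10000 nM. Compound 1 reaches only the limit of this assay, at > 30000 nM, so its true number is not known. The step of an at least 3.0-fold higher number from compound 3 to compound 1 (0.47 log units; beyond the scatter) therefore rests on the limit of > 30000 nM in this assay, at which 1 of the 3 values shown sits, and sets a floor on the change rather than its full size.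

Compound 2 `CCN(CC)C(=O)c1ccc(-c2cc(-c3cc(OC)ccc3OC)no2)s1` carries a different core; how the two cores differ is not broken down here. In this assay compound 2 gives 11000 nM, and against compound 3 this lies within the scatter. Compound 4 `COc1ccc(OC)c(-c2cc(-c3ccc(C(=O)N(C)C)s3)on2)c1` arises from compound 2 by the same change: dimethylamino in place of diethylamino on a carbonyl carbon. Because an at least 3.0-fold higher number from compound 3 to compound 1 (0.47 log units; beyond the scatter) made the number at least modestly higher, compound 4 is expected to give a higher number than compound 2 as well, though on a different core the step need not carry over in full. The step of a 2.7-fold higher number from compound 2 to compound 4 (0.44 log units; beyond the scatter) is an expectation only. Compound 4 is estimated at 30000 nM, within a range from 12000 nM to 80000 nM.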

Compound 4, half-maximal inhibitory concentration: > 30000 nM
Compound 4: no number, only a limit; the forecaster's own chance of this, stated with the estimate: 50%; the middle value lies on the limit itself.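

Compound 4 reaches only a limit in this assay, at > 30000 nM. Replacing diethylamino with dimethylamino on the carbonyl carbon gives an at least 2.7-fold higher number from compound 2 to compound 4 (0.43 log units; beyond the scatter), so the number moves the same way on both cores, and the direction of the change carries over in this small set. The true size of each step remains unknown, so the two cores share a direction, but it cannot be said whether the change has a larger effect on one core than on the other: the same change on two cores in this assay, an at least 3.0-fold higher number (0.47 log units; beyond the scatter) from compound 3 to compound 1 and an at least 2.7-fold higher number (0.43 log units; beyond the scatter) from compound 2 to compound 4; the limit leaves it open whether they differ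

The compounds shown carry only diethylamino and dimethylamino at this carbonyl carbon, which leaves open how a longer chain such as dipropylamino, or a ring amine such as piperidine, would read in this assay. Two cores are also too few to tell whether the same direction would hold on a third core.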